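The source may report more compounds than this note shows. Statements on the series, on what has been measured and on what is new or still open speak of the compounds shown alone.

Working notes on the series. In an ADME assay on Vero cells (Chlorocebus sabaeus) for cytotoxicity, read by resazurin assay, with a stated time of 72 h (on this read-out higher numbers stand for weaker inhibition and lower numbers for stronger inhibition), compound 1 (`O=C(CCN1CCN(c2ccc(Cl)cc2)CC1)c1ccc(F)c(Br)c1`) gives 206000 nM, compound 2 (`O=C(CCN1CCN(c2ccc(Cl)cc2)CC1)c1ccc(F)c(Cl)c1`) gives 114000 nM and compound 3 (`O=C(CCN1CCN(c2ccc(F)cc2)CC1)c1ccc(Cl)c(F)c1`) gives 105000 nM. Compound 3 lies within the scatter of both other compounds, so these three numbers do not separate.

The next compound is compound 4 (`O=C(CCN1CCN(c2ccc(Cl)cc2)CC1)c1ccc(Cl)c(F)c1`), which differs from compound 3 by chloro in place of fluoro on an aromatic carbon. In words, this is chloro in place of fluoro on an aromatic carbon, para to a large group, or 4-fluorophenyl to 4-chlorophenyl.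

No exchange of fluoro for chloro has been measured in this series. For the measured compounds named here, the only measured step between compounds differing in one place is a 1.8-fold lower number from compound 1 to compound 2 (0.26 log units; within the scatter), with chloro in place of bromo on an aromatic carbon. That step lies elsewhere in the molecule, so it bears on the present change only indirectly. Compound 2 already carries the 4-chlorophenyl group expected in compound 4. Compound 2, at 114000 nM, lies within the scatter of compound 3, at 105000 nM.

In this assay, no step beyond the scatter is therefore expected, and neither direction is favoured. The expected change is no change at the digits printed from compound 3 to compound 4 (within the scatter). The estimate for compound 4 is 105000 nM, with an expected range of 60000 nM to 190000 nM.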

Compound 4, half-maximal inhibitory concentration: 175000 nM
Estimate against measurement, compound 4: 1.7-fold (0.22 log units) below; the measured number falls inside the stated range.
By their numbers in this assay, from the lowest: compounds 3, 2, 4 and 1 (each within the scatter of the next).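

In this assay, for the compounds shown here, the first exchange of fluoro for chloro at this position, on an aromatic carbon para to a large group, gives a 1.7-fold higher number from compound 3 to compound 4 (0.22 log units; within the scatter) and so does not separate 4-fluorophenyl from 4-chlorophenyl on this read-out. The changes on the carbonyl carbon give the same picture: 4-chloro-3-fluorophenyl in place of 3-chloro-4-fluorophenyl gives a 1.5-fold higher number from compound 2 to compound 4 (0.19 log units; within the scatter) and 4-chloro-3-fluorophenyl in place of 3-bromo-4-fluorophenyl gives a 1.2-fold lower number from compound 1 to compound 4 (0.07 log units; within the scatter) and neither of these halogen arrangements stands apart from the others. Nothing available gives a reason for these small differences.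

From the compounds shown here alone, whether a group other than a halogen at this position, such as methoxy, an amine or a carboxylic acid, would give a step beyond the scatter remains open. Going by these compounds, it also remains open whether a longer chain in place of the one joining the carbonyl to the rest of the shared core would change the picture in this assay at all.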